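Swapping Nitro for Bromo: Compound 2 to Compound 4

The compounds below may be only part of what the source reports. "The series", "measured", "known", "first", "only" and "open" are said of these compounds alone.

Measured so far in an assay for inhibition of histone acetyltransferase KAT2B (Homo sapiens), read by fluorescence; on this read-out higher numbers stand for weaker inhibition and lower numbers for stronger inhibition:
compound 1 `O=c1c2cc([N+](=O)[O-])cnc2sn1-c1ccc([N+](=O)[O-])cc1` gives 11800 nM
compound 2 `O=c1c2cccnc2sn1-c1ccc([N+](=O)[O-])cc1` gives 4100 nM
compound 3 `O=c1c2cccnc2sn1Cc1ccc(Cl)cc1` gives 17500 nM

Compound 2 has the lowest number of the three, so it is the strongest inhibitor here; compound 1 is next and compound 3 furthest away, both beyond the scatter. Among the compounds with values here, the only single change measured is a 2.9-fold lower number from compound 1 to compound 2 (0.46 log units; beyond the scatter), which removes a nitro from the shared core and leaves the nitro on the phenyl ring untouched.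

Compound 4 `O=c1c2cccnc2sn1-c1ccc(Br)cc1` differs from compound 2 in this way: bromo in place of nitro on an aromatic carbon. Within the data shown here, no measured pair shows what happens at that place. The step from compound 1 to compound 2 concerns a nitro elsewhere, and compound 3 differs from compound 2 in two ways at once, so its value tells little about a bromo on its own. With no guidance in hand, and given that compound 2 already sits at the low end, the expectation for compound 4 is a number not far from compound 2, with a wide range that reaches toward weaker inhibition. That would mean a step of a 1.7-fold higher number from compound 2 to compound 4 (0.23 log units; within the scatter) is expected. For compound 4 the estimate is 7000 nM, between 2500 nM and 25000 nM.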

Compound 4, half-maximal inhibitory concentration: 4430 nM
Estimate against measurement, compound 4: 1.6-fold (0.20 log units) above, and the stated range covers the measured number.
By their numbers in this assay, from the lowest: compounds 2 and 4 (each within the scatter of the next); then compounds 1 and 3 (each within the scatter of the next).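

In this assay, putting bromo in place of nitro on the six-membered aromatic ring of carbon only gives a 1.1-fold higher number from compound 2 to compound 4 (0.03 log units; within the scatter), so compound 2 and compound 4 cannot be told apart by this measurement. Within the data shown here, this is the first reading at this position, and it shows that, on this core, inhibition at this level does not depend on the nitro: the nitro has 3 heavy atoms and 2 hydrogen-bond acceptors, while the bromo that replaces it has 1 heavy atom and 0 hydrogen-bond acceptors. No measurement at hand accounts for why these two different groups read alike.

The compounds shown carry only nitro and bromo at this place among close pairs, so it remains open whether a plain hydrogen, an amine or a carboxylic acid there would read the same or shift the number beyond the scatter. Also open, going by these compounds, is whether the swap would read the same with the extra nitro on the shared core that compound 1 carries.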